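A few compounds are considered here, and "the series" means these few. Any claim that something is new, unique, unknown or untested is made for them only; others in the source may bear on it.

Values in a functional assay on U-251 cells (Homo sapiens) for inhibition, read by sulforhodamine B assay, with a stated time of 72 h (on this read-out higher numbers stand for an effect only at larger amounts of compound and lower numbers for an effect already at smaller amounts), for the compounds measured so far:
- compound 1 `O=C(/C=C/c1ccc([N+](=O)[O-])o1)c1ccc(Br)cc1` gives 21400 nM
- compound 2 `O=C(/C=C/c1ccc([N+](=O)[O-])o1)c1ccc(N2CCCC2)cc1` gives 35900 nM
- compound 3 `O=C(/C=C/c1ccc([N+](=O)[O-])o1)c1ccc(-c2ccccc2)cc1` gives 24600 nM

The three values lie within the scatter of one another, so compound 3 has no distinct rank among them. The steps that reach it are a 1.1-fold higher number from compound 1 to compound 3 (0.06 log units; within the scatter) and a 1.5-fold lower number from compound 2 to compound 3 (0.16 log units; within the scatter) and neither separates it from the others.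

The next compound, compound 4 `O=C(/C=C/c1ccc([N+](=O)[O-])o1)c1ccc(N2CCNCC2)cc1`, has not yet been measured. It carries piperazin-1-yl in place of phenyl on an aromatic carbon, para to a large group piperazin-1-yl in place of phenyl on an aromatic carbon in the change from compound 3.

For the measured compounds named here, the closest precedent is the exchange of pyrrolidin-1-yl and phenyl at that carbon, a 1.5-fold lower number from compound 2 to compound 3 (0.16 log units; within the scatter) as the step. The remaining step, a 1.7-fold higher number from compound 1 to compound 2 (0.22 log units; within the scatter) is equally small. Piperazin-1-yl itself has no measured precedent here, so the range is kept wide. No step beyond the scatter is therefore expected in this assay for this change. The expected step is a 1.1-fold higher number from compound 3 to compound 4 (0.06 log units; within the scatter) and it stays small. The value estimated for compound 4 is 28000 nM (expected range 12000 nM to 55000 nM).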

Compound 4, half-maximal effective concentration: 16700 nM
Beside the measured number, compound 4's estimate is 1.7-fold (0.22 log units) above it; the measured number falls inside the stated range.
By their numbers in this assay, from the lowest: compounds 4, 1, 3 and 2 (each within the scatter of the next, the first and the last beyond it).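

In this assay, for the compounds shown here, piperazin-1-yl gives the first step that passes the scatter, a 2.1-fold lower number from compound 2 to compound 4 (0.33 log units; beyond the scatter) in a modest move, with piperazin-1-yl in place of pyrrolidin-1-yl on the aromatic carbon para to a large group. Against the other two groups the change stays within the scatter, with a 1.5-fold lower number from compound 3 to compound 4 (0.17 log units; within the scatter) for phenyl and a 1.3-fold lower number from compound 1 to compound 4 (0.11 log units; within the scatter) for bromo, so piperazin-1-yl stands apart from pyrrolidin-1-yl alone. No evidence at hand gives a reason for this difference.

The compounds shown leave open whether the step depends on the amine hydrogen of piperazin-1-yl or on the ring as a whole. A morpholine ring or a piperazine ring bearing a methyl group on that nitrogen at the same carbon would bear on this question.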